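Chain length in selenocyanate carbamates: a hexyl ester

This account rests on a few compounds, and the source may have more. Where it says the series, first, only, none or still open, it means among the compounds named here.

Three compounds sharing one core were measured in a functional assay on MCF7 cells (Homo sapiens) for cytotoxicity, read by MTT assay, with a stated time of 72 h; a higher number here means a weaker inhibitor of growth, a lower number a stronger inhibitor of growth:

Compound 1 `CCCOC(=O)Nc1ccc([Se]C#N)cc1`: 34400 nM
Compound 2 `CCOC(=O)Nc1ccc([Se]C#N)cc1`: 36700 nM
Compound 3 `N#C[Se]c1ccc(NC(=O)OCC2=Cc3ccccc3S2(=O)=O)cc1`: 34900 nM

Compound 2 stands together with compound 1 and compound 3, all three numbers lying within the scatter of one another. Within the data shown here, the step of a 1.1-fold higher number from compound 1 to compound 2 (0.03 log units; within the scatter) is the only measured change at the ester chain, and it shows nothing beyond the scatter. Compound 4 `CCCCCCOC(=O)Nc1ccc([Se]C#N)cc1` extends this chain further: butyl in place of hydrogen on a saturated chain carbon, two bonds along the chain from an oxygen next to a carbonyl group. Among the measured compounds shown here, since the one relevant step a 1.1-fold higher number from compound 1 to compound 2 (0.03 log units; within the scatter) was flat, and the bulkier ester of compound 3 gives 34900 nM, no change beyond the scatter is expected in this assay for compound 4, though a longer chain has not been tested and adds uncertainty. Compound 4 is therefore estimated at 30000 nM, ranging from 13000 nM to 70000 nM, an expected step of a 1.2-fold lower number from compound 2 to compound 4 (0.09 log units; within the scatter).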

Compound 4, concentration for total growth inhibition: 30500 nM
The estimate for compound 4 lay 1.0-fold (0.01 log units) below the measured number, within the range that was stated.
By their numbers in this assay, from the lowest: compounds 4, 1, 3 and 2 (each within the scatter of the next).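

In this assay butyl in place of hydrogen on the ester chain brings a 1.2-fold lower number from compound 2 to compound 4 (0.08 log units; within the scatter) and propyl in place of hydrogen brings a 1.1-fold lower number from compound 1 to compound 4 (0.05 log units; within the scatter) and so neither step leaves the scatter. The flat reading at this position, earlier seen only for the change between hydrogen and methyl, therefore holds out to the hexyl ester. Nothing available explains this flat reading.

As far as these compounds go, whether a chain longer than hexyl or a branched chain would move the number beyond the scatter stays open. So does the effect of an ester chain carrying an amine or a carboxylic acid.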